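The compounds below may be only part of what the source reports. "The series", "measured", "known", "first", "only" and "open" are said of these compounds alone.

In an ADME assay on microsomes from liver (Rattus norvegicus) for metabolic stability, read by LC-MS, using NADPH, at 37 degrees C (a lower number here means that the compound disappears faster, a higher number that the compound lasts longer), compound 1 `COc1cccc(Cl)c1-c1nc(CN2CCC(C(=O)NCCCN3C[C@H](C)C[C@H](C)C3)CC2)c(C)o1` gives 0.055 h. Compound 2 `Cc1ccc(-c2nc(CN3CCC(C(=O)NCCCN4C[C@H](C)C[C@H](C)C4)CC3)c(C)o2)c(C)c1` gives > 0.5 h, which is a limit of the assay and not a number. Within the data shown here, the one measured step, which put 2,4-dimethylphenyl in place of 2-chloro-6-methoxyphenyl, is an at least 9.0-fold higher number from compound 1 to compound 2 (0.95 log units; beyond the scatter). Compound 3 `Cc1cc(C)cc(-c2nc(CN3CCC(C(=O)NCCCN4C[C@H](C)C[C@H](C)C4)CC3)c(C)o2)c1` has 3,5-dimethylphenyl in place of 2,4-dimethylphenyl (3,5-dimethylphenyl in place of 2,4-dimethylphenyl on an aromatic carbon). Among the measured compounds shown here, only that measured step bears on this change, and it exchanged different groups, so no step of its size is expected here. In this assay the expected step is an at least 1.2-fold lower number from compound 2 to compound 3 (0.09 log units; that floor lies within the scatter), which would lie within the scatter. For compound 3 the expected value is 0.4 h, with an estimated range from 0.12 h to 1 h.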

Compound 3, half-life: < 0.5 h
Compound 3 ended at the assay's limit (the forecaster's own chance of this, stated with the estimate: 40%); the middle value lies beyond the limit too.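

3,5-Dimethylphenyl in place of 2,4-dimethylphenyl keeps the same atoms, joined differently, yet in this assay it gives a number no higher from compound 2 to compound 3 (the limit leaves the size open). The outcome at this position is therefore not set by the atoms of the group alone. The steps from compound 2 and from compound 1 to compound 3 cannot be read in size, because compound 3 sits at a limit: the limit of < 0.5 h in this assay, at which 1 of the 3 values shown sits.

From the compounds shown here alone, how far compound 3 lies from that limit stays open. So does what a plain phenyl or a 3,5-dichlorophenyl would give at this position.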